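The source may report more compounds than this note shows. Statements on the series, on what has been measured and on what is new or still open speak of the compounds shown alone.

Compound 1 `CCCCNc1nc(N)nc2c1CCNC2`: 0.6 uM in an assay on HEK293 cells for agonist activity at Toll-like receptor 8 (Homo sapiens), read by a luciferase reporter, with a stated time of 6 h; a higher number here means that more compound is needed for the effect, a lower number that less compound is needed
Compound 2 `CCCCNc1nc(N)nc2c1CN(Cc1ccc(OC)cc1)CC2`: 0.08 uM in this assay
Compound 3 `CCCCNc1nc(N)nc2c1CN(Cc1cccnc1)CC2`: 0.13 uM in this assay

Compound 3 stands second highest of the three numbers; its nearest neighbour is compound 2, with a 1.6-fold higher number from compound 2 to compound 3 (0.21 log units; within the scatter), and its furthest is compound 1, whose number is beyond the scatter above it. From the compounds shown here alone, compound 4 `CCCCNc1nc(N)nc2c1CN(C(=O)c1csc(N)n1)CC2` is untested. It differs from compound 3 by (2-amino-1,3-thiazol-4-yl)carbonyl in place of (pyridin-3-yl)methyl on an amine nitrogen in a ring. For the measured compounds named here, only one measured step touches the same ring nitrogen: a 1.6-fold higher number from compound 2 to compound 3 (0.21 log units; within the scatter), a swap of one aromatic ring for another that left the number essentially unchanged. Going by the values given here, no measured step covers the exchange of a saturated chain carbon for a carbonyl at that position, so the expectation is uncertain. Compound 4 is expected to give a somewhat higher number, a 2.3-fold higher number from compound 3 to compound 4 (0.36 log units; beyond the scatter), with an estimate of 0.3 uM and a range from 0.08 uM to 1.2 uM in this assay.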

Compound 4, minimum effective concentration: 6.9 uM
The estimate for compound 4 lay 23-fold (1.36 log units) below the measured number; measured number above the stated range.
By their numbers in this assay, from the lowest: compounds 2 and 3 (each within the scatter of the next); then compound 1; then compound 4.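

The step of a 1.6-fold higher number from compound 2 to compound 3 (0.21 log units; within the scatter) made this ring nitrogen look forgiving, but the step of a 53-fold higher number from compound 3 to compound 4 (1.72 log units; beyond the scatter) shows that the group on it can matter a great deal. This change swaps both the saturated chain carbon for a carbonyl and the pyridin-3-yl ring for the 2-amino-1,3-thiazol-4-yl ring, so neither part alone can be held responsible. Nothing available explains the size of this step. Which part carries the rise stays open: a (pyridin-3-yl)carbonyl or a (2-amino-1,3-thiazol-4-yl)methyl group on the same nitrogen would separate the two.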